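Putting 2-(diethylamino)ethyl in place of hydroxy

The compounds below may be only part of what the source reports. "The series", "measured", "known", "first", "only" and "open" are said of these compounds alone.

Compound 1 (`CN(C)CCn1c(N)c(-c2nc3ccccc3[nH]2)c2nc(C#N)c(C#N)nc21`): 8320 nM
Compound 2 (`N#Cc1nc2c(-c3nc4ccccc4[nH]3)c(N)n(CCO)c2nc1C#N`): 5520 nM

Within the data shown here, in a functional assay on Raji cells (Homo sapiens) for antiproliferative activity, read by MTT assay, with a stated time of 48 h (on this read-out higher numbers stand for weaker inhibition and lower numbers for stronger inhibition), compound 2 stands level with compound 1, the only other measured compound, with a 1.5-fold lower number from compound 1 to compound 2 (0.18 log units; within the scatter). Compound 3 (`CCN(CC)CCCCn1c(N)c(-c2nc3ccccc3[nH]2)c2nc(C#N)c(C#N)nc21`) has not yet been measured. It has 2-(diethylamino)ethyl in place of the hydroxy of compound 2, on a saturated chain carbon, two bonds along the chain from an aromatic nitrogen: 2-(diethylamino)ethyl in place of hydroxy on a saturated chain carbon, two bonds along the chain from an aromatic nitrogen. Among the measured compounds shown here, one measured step bears on this change, the exchange at that same place between compound 1 and compound 2, which gave a 1.5-fold lower number from compound 1 to compound 2 (0.18 log units; within the scatter). For the measured compounds named here, no measured compound carries the 4-(diethylamino)butyl chain, so the expectation stays wide. No step beyond the scatter is expected in this assay. The expected step is a 1.2-fold higher number from compound 2 to compound 3 (0.07 log units; within the scatter). The estimated value for compound 3 is 6500 nM, with an expected range of 2500 nM to 16000 nM.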

Compound 3, half-maximal inhibitory concentration: 2640 nM
Compound 3: middle estimate off by 2.5-fold (0.39 log units), on the high side, and the stated range covers the measured number.
By their numbers in this assay, from the lowest: compound 3; then compounds 2 and 1 (each within the scatter of the next).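

In this assay the chain on the aromatic nitrogen proves able to move the number beyond the scatter: putting 2-(diethylamino)ethyl in place of hydroxy gives a 2.1-fold lower number from compound 2 to compound 3 (0.32 log units; beyond the scatter) and putting it in place of dimethylamino gives a 3.2-fold lower number from compound 1 to compound 3 (0.50 log units; beyond the scatter) while the earlier exchange of dimethylamino for hydroxy stayed within the scatter. Both new steps are modest, yet they make compound 3, with its 4-(diethylamino)butyl chain, the most potent of the three. The data offer no measurement that accounts for this gain.

The compounds shown leave open whether the step belongs to the longer chain or to the ethyl groups on the amine, as the two change together in compound 3. A 4-(dimethylamino)butyl chain or a 4-hydroxybutyl chain on the same nitrogen would separate the two.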